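The source may report more compounds than this note shows. Statements on the series, on what has been measured and on what is new or still open speak of the compounds shown alone.

The measured compounds are:

Compound 1 `COc1ccc(-c2cnc(NC(=O)c3cccc([N+](=O)[O-])c3)n2C)cc1` in a toxicity assay on THP-1 cells (Homo sapiens) for inhibition; on this read-out higher numbers stand for lower toxicity in this test and lower numbers for higher toxicity in this test: > 100000 nM
Compound 2 `Cn1c(-c2ccc(Br)cc2)cnc1NC(=O)c1ccc(F)cc1`: 46000 nM
Compound 3 `COc1ccc(-c2cnc(NC(=O)c3cccnc3)n2C)cc1`: > 100000 nM

For compound 3 the result is a limit of the assay and not a number. The same holds for compound 1, so that two of the three readings sit at that limit (the limit of > 100000 nM in this assay, at which 2 of the 3 values shown sit), and only compound 2 has a numerical value. Among the measured compounds shown here, compound 3 therefore stands at the upper edge of what this test can report, with no measured step connecting it to any other compound.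

Compound 4 `COc1ccc(-c2cnc(NC(=O)c3ccc(C)cc3)n2C)cc1` is the untested compound. It differs from compound 3 in one place (4-methylphenyl in place of pyridin-3-yl on a carbonyl carbon). For the measured compounds named here, no measured pair shows the effect of such an exchange here, so the expected step from compound 3 to compound 4 is one of no movement beyond the usual scatter, with the result most likely remaining a limit.

Compound 4 is expected to give 100000 nM, within a range from 40000 nM to 250000 nM.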

Compound 4, half-maximal cytotoxic concentration: > 100000 nM
Compound 4: only a limit was reported; the forecaster's own chance of this, stated with the estimate: 60%; the middle value lies on the limit itself.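

No step can be read between compound 3 and compound 4, because both results are limits of the assay: the limit of > 100000 nM in this assay, at which 3 of the 4 values shown sit.

The compounds shown leave open whether 4-methylphenyl in place of pyridin-3-yl on a carbonyl carbon changes the result in this assay at all.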